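This account rests on a few compounds, and the source may have more. Where it says the series, first, only, none or still open, it means among the compounds named here.

In a physicochemical assay for lipophilicity (on this read-out higher numbers stand for higher lipophilicity and lower numbers for lower lipophilicity), compound 1 `COc1cc(C2=NO[C@]3(C2)C(=O)O[C@@H]2[C@H]3CC[C@H](C)[C@]3(O)C=CC(=O)[C@@]23C)ccc1O` gives 0.75 as its reading, and compound 2 `C[C@H]1CC[C@@H]2[C@@H](OC(=O)[C@]23CC(c2cccc([N+](=O)[O-])c2)=NO3)[C@]2(C)C(=O)C=C[C@@]12O` gives 1.37 as the higher of the two numbers. For the measured compounds named here, the one measured step is a number 0.62 log units higher from compound 1 to compound 2 (beyond the scatter) and comes with 3-nitrophenyl in place of 4-hydroxy-3-methoxyphenyl. Compound 3 `C[C@H]1CC[C@@H]2[C@@H](OC(=O)[C@]23CC(c2ccc(C#N)cc2)=NO3)[C@]2(C)C(=O)C=C[C@@]12O` keeps the shared core and differs from compound 2 on a carbon with a double bond to nitrogen, with 4-cyanophenyl in place of 3-nitrophenyl, the full count being 4-cyanophenyl in place of 3-nitrophenyl on a carbon with a double bond to nitrogen for this exchange. Going by the values given here, no measured step exchanges these two groups, so the step of a number 0.62 log units higher from compound 1 to compound 2 (beyond the scatter) offers only a loose guide to size. The expected move in this assay is small and slightly downward, within the scatter, estimated as a number 0.15 log units lower from compound 2 to compound 3 (within the scatter) overall. For compound 3 the estimate is 1.22 with an expected range from 0.85 to 1.6 in this read-out.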

Compound 3, partition coefficient: 1.17
The estimate for compound 3 lay 0.05 log units above the measured number; low and high end bracket the measured number.
By their numbers in this assay, from the lowest: compound 1; then compounds 3 and 2 (each within the scatter of the next).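

In this assay, 4-cyanophenyl in place of 3-nitrophenyl on the carbon with a double bond to nitrogen gives a number 0.20 log units lower from compound 2 to compound 3 (within the scatter), so these two groups cannot be told apart on this read-out. The exchange of 4-hydroxy-3-methoxyphenyl for 4-cyanophenyl at this position gives a number 0.42 log units higher from compound 1 to compound 3 (beyond the scatter), which means that a second group, besides 3-nitrophenyl, now stands clear of compound 1 in the same direction. Nothing available accounts for these readings.

Compounds 2 and 3 differ in both the substituent and its number on the phenyl ring, so 3-cyanophenyl and 4-nitrophenyl would be needed to separate the two changes. All three compounds also carry an aromatic ring here, which leaves open what an amine or a carboxylic acid on that ring, or a longer alkyl chain in its place, would give.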